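The source may report more compounds than this note shows. Statements on the series, on what has been measured and on what is new or still open speak of the compounds shown alone.

Measured compounds:
- compound 1 `CC(C)=CC(=O)Nc1cc2c(N3CCc4ccccc43)ncnc2cc1O[C@@H]1CCOC1` gives 4620 nM
- compound 2 `CC(C)/C=C/C(=O)Nc1cc2c(N3CCc4ccccc43)ncnc2cc1O[C@@H]1CCOC1` gives 11200 nM
- compound 3 `O=C(/C=C/CN1CCC(CO)CC1)Nc1cc2c(N3CCc4ccccc43)ncnc2cc1O[C@@H]1CCOC1` gives 3310 nM

All three were tested in a functional assay on PC-3 cells (Homo sapiens) for antiproliferative activity, read by MTT assay, with a stated time of 72 h; on this read-out lower numbers stand for stronger inhibition and higher numbers for weaker inhibition. Compound 3 has the lowest of the three numbers; its nearest neighbour is compound 1, and the two values lie within the usual scatter of each other, while the furthest step is a 3.4-fold lower number from compound 2 to compound 3 (0.53 log units; beyond the scatter).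

Compound 4 `O=C(/C=C/CN1CCC(CO)CC1)Nc1cc2c(N3CCCc4ccccc43)ncnc2cc1O[C@@H]1CCOC1` differs from compound 3 in one place: 1,2,3,4-tetrahydroquinolin-1-yl in place of 2,3-dihydro-1H-indol-1-yl on an aromatic carbon. Among the compounds with values here, every measured step so far changed the chain on the carbonyl carbon instead, namely a 2.4-fold higher number from compound 1 to compound 2 (0.38 log units; beyond the scatter) and a 1.4-fold lower number from compound 1 to compound 3 (0.14 log units; within the scatter), so none of them bears on a change at this aromatic carbon. With nothing to point either way, the expectation for compound 4 is a number close to that of compound 3, with no step beyond the scatter, and the expected step is a 1.1-fold higher number from compound 3 to compound 4 (0.02 log units; within the scatter). In this assay compound 4 is therefore estimated at 3500 nM, with a range from 1200 nM to 10000 nM.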

Compound 4, half-maximal inhibitory concentration: 5460 nM
The estimate for compound 4 lay 1.6-fold (0.19 log units) below the measured number, within the range that was stated.
By their numbers in this assay, from the lowest: compounds 3, 1 and 4 (each within the scatter of the next); then compound 2.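

Within the data shown here, compound 4 gives the first reading at the aromatic carbon next to the ring nitrogen, since the earlier compounds all carry 2,3-dihydro-1H-indol-1-yl there. Replacing that group with 1,2,3,4-tetrahydroquinolin-1-yl, which has a six-membered rather than a five-membered non-aromatic ring, gives a 1.6-fold higher number from compound 3 to compound 4 (0.22 log units; within the scatter) in this assay, so this read-out does not separate the two groups at this position. No measurement is available to explain the result.

As far as these compounds go, it remains open whether this aromatic carbon would accept a group without a fused ring, such as morpholin-4-yl or a simple dimethylamino group. It is also unknown whether 1,2,3,4-tetrahydroquinolin-1-yl would behave the same way alongside the 2-methylprop-1-en-1-yl chain of compound 1.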